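The source may report more compounds than this note shows. Statements on the series, on what has been measured and on what is new or still open speak of the compounds shown alone.

Compound 2 `CCn1c(C(=O)Nc2cccc(C(F)(F)F)c2)ccc1C(CC)(CC)c1ccc(OCCC(O)(CC)CC)c(C)c1` carries on the amide-type nitrogen a 3-(trifluoromethyl)phenyl group. In a functional assay on HepG2 cells (Homo sapiens) for antiproliferative activity, read by MTT assay, with a stated time of 48 h (a higher number here means a weaker inhibitor, a lower number a stronger inhibitor), compound 2 reaches only the limit of the assay, > 50000 nM. Compound 1 `CCn1c(C(=O)N(CCC#N)CCC#N)ccc1C(CC)(CC)c1ccc(OCCC(O)(CC)CC)c(C)c1` carries on the same carbonyl carbon a nitrogen bearing two chains that end in nitrile groups, and in this assay compound 1 gives 46300 nM. Within the data shown here, the one measured step is an at least 1.0-fold higher number from compound 1 to compound 2 (0.03 log units; that floor lies within the scatter); since compound 2 sits at the limit of > 50000 nM in this assay, at which 1 of the 2 values shown sits, only a floor for that step is known, and it lies within the scatter. Both measured compounds thus stand at the weak end of what this assay can report.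

Compound 3 `CCn1c(C(=O)NC(CO)CCO)ccc1C(CC)(CC)c1ccc(OCCC(O)(CC)CC)c(C)c1` differs from compound 2 only on the amide-type nitrogen: 3-hydroxy-1-(hydroxymethyl)propyl in place of 3-(trifluoromethyl)phenyl on an amide-type nitrogen. Among the measured compounds shown here, no measured step covers a ring exchanged for a hydroxylated chain here; the single step on this nitrogen stayed within the scatter. The expected step is therefore a number no higher from compound 2 to compound 3 (the limit leaves the size open), none beyond the scatter, with a good chance that this assay again reports only a limit. Compound 3 is expected to give 50000 nM in this assay, within 15000 nM to 150000 nM.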

Compound 3, half-maximal inhibitory concentration: 24800 nM
The estimate for compound 3 lay 2.0-fold (0.30 log units) above the measured number, within the range that was stated.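

With 3-hydroxy-1-(hydroxymethyl)propyl in place of 3-(trifluoromethyl)phenyl on an amide-type nitrogen, this assay returns a number rather than a limit, and the change gives an at least 2.0-fold lower number from compound 2 to compound 3 (0.30 log units; that floor lies within the scatter). The size of that step remains a floor, and its true size stays unknown, since one end of it is a limit and not a number: the limit of > 50000 nM in this assay, at which 1 of the 3 values shown sits.

The hydroxylated chain and the two nitrile-ended chains on the same carbonyl carbon are not separated, with a 1.9-fold lower number from compound 1 to compound 3 (0.27 log units; within the scatter), so the three groups measured so far, with and without a ring, leave the series at the weak end of this assay with no step shown beyond the scatter.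

The compounds shown leave open whether the hydroxyl groups of compound 3 matter at all, which a plain butyl chain on the same nitrogen would test against the 3-hydroxy-1-(hydroxymethyl)propyl group. They also leave open whether any group at this place can move the number beyond the scatter, for example a primary amine or a carboxylic acid at the end of the chain.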